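This account rests on a few compounds, and the source may have more. Where it says the series, first, only, none or still open, it means among the compounds named here.

Among the measured compounds shown here, compound 2 `C[C@]1(C(=O)N2CC[C@](c3ccc(C(F)(C(F)(F)F)C(F)(F)F)cc3)(S(=O)(=O)c3ccc(F)cc3)C2)CC[C@@H](C(=O)O)CC1` is the one member of this set with a result in hand: in an ADME assay on microsomes from liver (Homo sapiens) for metabolic stability, with a stated time of 10 min (on this read-out lower numbers stand for a less stable compound and higher numbers for a more stable compound), compound 2 gives 85%. Compound 1 `O=C(O)[C@H]1CC[C@](F)(C(=O)N2CC[C@](c3ccc(C(F)(C(F)(F)F)C(F)(F)F)cc3)(S(=O)(=O)c3ccc(F)cc3)C2)CC1` was also entered in this assay, where compound 1 gives "not determined" (no result reported), so on the figures that exist compound 2 stands alone and nothing can be said about where compound 1 sits relative to it. Compound 3 `O=C(N1CC[C@](c2ccc(C(F)(C(F)(F)F)C(F)(F)F)cc2)(S(=O)(=O)c2ccc(F)cc2)C1)C1(F)CCS(=O)(=O)CC1` has not been measured. It differs from compound 2 in one place: 4-fluoro-1,1-dioxothian-4-yl in place of 4-carboxy-1-methylcyclohexyl on a carbonyl carbon. For the measured compounds named here, no step between two measured compounds is available, so there is no measured precedent for what such a change does in this assay, and the expectation for compound 3 can rest only on the single value of compound 2 and on the change itself. The step from compound 2 to compound 3 is expected to be a number 5 percentage points lower from compound 2 to compound 3 (within the scatter), that is, no change beyond the scatter or at most a small loss. Compound 3 is therefore estimated at 80% in this assay, with a range from 60% to 95%.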

Compound 3, percent of the compound remaining: 100%
Compound 3: the middle estimate sits 20 percentage points below what was measured; the whole stated range lies below it.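

In this assay, among the compounds shown here, replacing 4-carboxy-1-methylcyclohexyl with 4-fluoro-1,1-dioxothian-4-yl on a carbonyl carbon gives a number 15 percentage points higher from compound 2 to compound 3 (beyond the scatter), the first measured step at this place. It shows that, with the rest of the structure unchanged, the carboxylic acid of compound 2 is not required for a high reading here, since compound 3 lacks that group and still reads higher, by a margin beyond the usual scatter. Nothing shown here gives a measured reason for the rise, and the change alters the ring, the substituents and the hydrogen-bond count all at once.

The compounds shown leave open which part of the exchange carries the step: the sulfone in the ring, the fluorine, or the loss of the methyl and carboxylic acid groups. They also leave open how this place would respond to other groups on the same carbonyl carbon, such as an amine, a hydroxyl group or a plain cyclohexyl ring bearing only fluorine.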